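The source may report more compounds than this note shows. Statements on the series, on what has been measured and on what is new or still open speak of the compounds shown alone.

The three measured compounds share one core and differ only in the aryl group on the enone chain. Compound 1 `COc1cccc(/C=C/C(=O)c2ccc(OC)c3c2OC(C)(C)C=C3)c1` carries a 3-methoxyphenyl there, compound 2 `COc1ccc(C(=O)/C=C/c2cc(OC)c(OC)c(OC)c2)c2c1C=CC(C)(C)O2` a methoxy-bearing aryl of its own, and compound 3 `COc1ccc(C(=O)/C=C/c2ccc(N(C)C)cc2)c2c1C=CC(C)(C)O2` a 4-(dimethylamino)phenyl. For compound 1 the result in a functional assay on SW-620 cells (Homo sapiens) for antiproliferative activity, read by MTT assay, with a stated time of 24 h (on this read-out higher numbers stand for weaker inhibition and lower numbers for stronger inhibition), is > 10000 nM, which is the limit of > 10000 nM in this assay, at which 1 of the 3 values shown sits, and not a number. In this assay compound 2 gives 9150 nM and compound 3 gives 570 nM. Of the two numbers compound 3 stands lowest, with compound 2 as its nearest neighbour. The only single-place step shown is an at least 17-fold lower number from compound 1 to compound 3 (1.24 log units; beyond the scatter), a large drop.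

Compound 4 `COc1ccc(C(=O)/C=C/c2ccc([N+](=O)[O-])cc2)c2c1C=CC(C)(C)O2` differs from compound 3 by nitro in place of dimethylamino on an aromatic carbon. Within the data shown here, no measured step exchanges these two groups directly; the one step on the same ring, an at least 17-fold lower number from compound 1 to compound 3 (1.24 log units; beyond the scatter), shows only that the 4-(dimethylamino)phenyl is where the low number was found, and compound 4 gives that group up. Compound 4 is therefore expected to return a higher number in this assay, estimated at 3500 nM within a range from 900 nM to 12000 nM. The expected step is a 6.1-fold higher number from compound 3 to compound 4 (0.79 log units; beyond the scatter), upward and beyond the scatter.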

Compound 4, half-maximal inhibitory concentration: 3520 nM
Compound 4: the middle estimate sits 1.0-fold (0.00 log units) below what was measured; the measured number falls inside the stated range.
By their numbers in this assay, from the lowest: compound 3; then compound 4; then compound 2. At a limit, above all of these: compound 1.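

Exchanging dimethylamino for nitro on this aromatic carbon, para to a large group, gives a 6.2-fold higher number from compound 3 to compound 4 (0.79 log units; beyond the scatter) in this assay, so the low number of compound 3 belongs to the dimethylamino group and is not kept by every group of this size at this place. Among these compounds, the 4-nitrophenyl nevertheless keeps a measurable number, with an at least 2.8-fold lower number from compound 1 to compound 4 (0.45 log units; beyond the scatter), which shows that the 4-(dimethylamino)phenyl is not the only aryl group on the enone chain to fall below the 3-methoxyphenyl. That second step is only a bound, since compound 1 stands at a limit and not at a number: the limit of > 10000 nM in this assay, at which 1 of the 4 values shown sits.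

The compounds shown leave open whether the two methyl groups on the nitrogen matter, which a primary amine or a diethylamino group at the same place would test. They also do not separate the group from its place in the change away from the 3-methoxyphenyl, a question that a 4-methoxyphenyl on the same chain would address.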